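Benzyl swap on the shared core: cytotoxicity outlook

A few compounds are considered here, and "the series" means these few. Any claim that something is new, unique, unknown or untested is made for them only; others in the source may bear on it.

Compound 1 `CS(=O)(=O)Nc1ccc2c(c1)S(=O)(=O)N=C(C1=C(O)[C@H]3CCC[C@H]3N(Cc3ccc(F)c(F)c3)C1=O)N2` and compound 2 `CS(=O)(=O)Nc1ccc2c(c1)S(=O)(=O)N=C(C1=C(O)[C@H]3CCC[C@H]3N(Cc3ccc(F)c(Cl)c3)C1=O)N2` share one core and differ only on the benzyl ring. In an ADME assay on Huh-7 cells (Homo sapiens) for cytotoxicity, with a stated time of 72 h (on this read-out lower numbers stand for higher toxicity in this test and higher numbers for lower toxicity in this test), compound 1 gives > 1000 nM, which is a limit of the assay and not a number. In this assay compound 2 gives > 1000 nM, again a limit of the assay. The step that the two limits leave unreadable from compound 1 to compound 2 is therefore unreadable. Compound 2 stands at the limit, as does every value shown so far (the limit of > 1000 nM in this assay, at which 2 of the 2 values shown sit).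

Compound 3 `CS(=O)(=O)Nc1ccc2c(c1)S(=O)(=O)N=C(C1=C(O)[C@H]3CCC[C@H]3N(Cc3ccc(C(F)(F)F)cc3)C1=O)N2` differs from compound 2 by 4-(trifluoromethyl)phenyl in place of 3-chloro-4-fluorophenyl on a saturated chain carbon bound to an amide-type nitrogen in a ring. For the measured compounds named here, the only measured step, the one bearing on a change at the same benzyl ring, runs from one limit to another and gives no size. Going by the values given here, no measured step in this assay points to any direction. Since both values shown sit at the limit (the limit of > 1000 nM in this assay, at which 2 of the 2 values shown sit), compound 3 is expected to give a value at or beyond that limit too, with an expected step that the limit leaves unreadable from compound 2 to compound 3, nothing beyond the scatter. Compound 3 is estimated at 3000 nM, with a range from 1000 nM to 30000 nM.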

Compound 3, half-maximal cytotoxic concentration: > 33000 nM
Compound 3 was reported as a limit; the forecaster's own chance of this, stated with the estimate: 85%; middle value at least 11-fold (1.04 log units) from the limit.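

In this assay, for the compounds shown here, compound 1, compound 2 and compound 3 all give limits of the assay and not numbers, so no step among them can be read. The compounds shown leave open whether 3,4-difluorophenyl, 3-chloro-4-fluorophenyl and 4-(trifluoromethyl)phenyl differ at all in half-maximal cytotoxic concentration on the shared core.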